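The source may hold more compounds than are shown below. What is called first, only, known or untested is meant among the compounds shown, and "the series" means these compounds.

Working notes on the series in an ADME assay on CCRF-CEM cells (Homo sapiens) for cytotoxicity, with a stated time of 72 h; on this read-out higher numbers stand for weaker inhibition and lower numbers for stronger inhibition. Compound 1 `COc1ccc(-c2nc3sc(Cc4ccc(Cl)cc4)nn3c2C=O)cc1` gives 3800 nM, and compound 3 `COc1ccc(-c2nc3sc(Cc4ccc(Cl)cc4)nn3c2SC#N)cc1` gives 10000 nM; the step between them is a 2.6-fold higher number from compound 1 to compound 3 (0.42 log units; beyond the scatter), the change being (cyanosulfanyl in place of formyl on an aromatic carbon). Compound 2 `O=Cc1c(-c2cc3ccccc3oc2=O)nc2sc(Cc3ccc(Cl)cc3)nn12` gives 750 nM, the lowest of the three numbers. How the core of compound 2 differs from that of compound 1 is not broken down here.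

Compound 4 `N#CSc1c(-c2cc3ccccc3oc2=O)nc2sc(Cc3ccc(Cl)cc3)nn12` is not yet measured. From compound 2 it differs by cyanosulfanyl in place of formyl on an aromatic carbon. This is the same kind of change as from compound 1 to compound 3, though the place is described as next to the ring atom that bears a large group rather than the ring atom that bears a 4-methoxyphenyl group. The step from compound 2 to compound 4 is expected to be about a 2.7-fold higher number from compound 2 to compound 4 (0.43 log units; beyond the scatter) because the same kind of change gave a 2.6-fold higher number from compound 1 to compound 3 (0.42 log units; beyond the scatter). Compound 4 is therefore estimated at 2000 nM, with a range from 900 nM to 5000 nM.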

Compound 4, half-maximal inhibitory concentration: 1400 nM
Estimate against measurement, compound 4: 1.4-fold (0.15 log units) above, and the stated range covers the measured number.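

In this assay, the step from formyl to cyanosulfanyl on an aromatic carbon is a 1.9-fold higher number from compound 2 to compound 4 (0.27 log units; within the scatter). Set beside the earlier step, the change carries from one core to the other with no difference that can be told apart: the same change on two cores in this assay, a 2.6-fold higher number (0.42 log units; beyond the scatter) from compound 1 to compound 3 and a 1.9-fold higher number (0.27 log units; within the scatter) from compound 2 to compound 4, 1.4-fold (0.15 log units) apart, within the scatter of two such steps. This rests on two pairs in one read-out, so it does not show that the change would behave alike on any further core.

The compounds shown hold only formyl and cyanosulfanyl on this aromatic carbon, so how an amine or a carboxylic acid there would compare stays open. Also open, as far as these compounds go, is whether a longer chain in place of either group would follow the same course on both cores.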